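A few compounds are considered here, and "the series" means these few. Any claim that something is new, unique, unknown or untested is made for them only; others in the source may bear on it.

Measured compounds:
- compound 1, `O=C(NCCCc1ccccc1)c1csc(NC(=S)Nc2ccc(Cl)cc2)n1`: 32200 nM in a functional assay on HeLa cells (Homo sapiens) for antiproliferative activity, read by MTT assay, with a stated time of 72 h; a lower number here means a stronger inhibitor, a higher number a weaker inhibitor
- compound 2, `CCOC(=O)c1csc2nc(CN3CCN(C)CC3)c(-c3ccc(C)cc3)n12`: 43900 nM in this assay

Within the data shown here, compound 2 has the higher of the two numbers measured so far, but its value and that of compound 1 lie within the usual scatter of each other, so the two compounds cannot be told apart on these data. Both sit in a weak range, and the two share no common core, so nothing about the piperazine substituent can be read from compound 1.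

Compound 3, `CCOC(=O)c1csc2nc(CN3CCN(Cc4ccccc4)CC3)c(-c3ccc(C)cc3)n12`, differs from compound 2 in one place: phenyl in place of hydrogen on a saturated chain carbon bound to an amine nitrogen in a ring. The change sits on the saturated chain carbon bound to the amine nitrogen in the ring, far from the ester and the aryl group that compound 3 keeps unchanged from compound 2. Among the measured compounds shown here, with no measured pair of this kind to lean on, the step from compound 2 to compound 3 is expected to stay within the scatter, and the estimated step is a 1.5-fold lower number from compound 2 to compound 3 (0.17 log units; within the scatter). Compound 3 is therefore expected to give about 30000 nM, with a range from 10000 nM to 90000 nM.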

Compound 3, half-maximal inhibitory concentration: 38800 nM
Estimate against measurement, compound 3: 1.3-fold (0.11 log units) below; low and high end bracket the measured number.
By their numbers in this assay, from the lowest: compounds 1, 3 and 2 (each within the scatter of the next).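

Among these compounds, the pair gives the first reading at this position. In this assay phenyl in place of hydrogen on a saturated chain carbon bound to an amine nitrogen in a ring amounts to a 1.1-fold lower number from compound 2 to compound 3 (0.05 log units; within the scatter) and so the methyl and benzyl forms cannot be told apart, something compound 1, with its different core, could not show. Adding this six-membered aromatic ring of carbon therefore leaves both compounds in the same weak range, and no measurement at hand offers an explanation for the result.

Going by these compounds, what an amine, a carboxylic acid or a longer chain in place of the phenyl would do at this saturated chain carbon stays open, since a single step within the scatter says nothing about groups of another kind. Also open, on these data alone, is whether methyl to benzyl would read the same way if the ester kept by compound 2 and compound 3 gave way to a carboxylic acid or an amide.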